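The source may hold more compounds than are shown below. What is called first, only, known or untested is meant among the compounds shown, and "the series" means these compounds.

In a functional assay on PC-3 cells (Homo sapiens), read by MTT assay, with a stated time of 48 h (on this read-out higher numbers stand for weaker inhibition and lower numbers for stronger inhibition), compound 1 `CCn1c(C(=O)NCCN(C)C)ccc1C(CC)(CC)c1ccc(OCC(=O)C(C)(C)C)c(C)c1` gives 2300 nM and compound 2 `CCn1c(C(=O)NCCCN(C)C)ccc1C(CC)(CC)c1ccc(OCC(=O)C(C)(C)C)c(C)c1` gives 1600 nM. Compound 3 `CCn1c(C(=O)NCC(OC)OC)ccc1C(CC)(CC)c1ccc(OCC(O)C(C)(C)C)c(C)c1` stands at 14600 nM, the highest number of the three and beyond the scatter from both others. Compound 4 `C#CC(C)OC(=O)c1ccc(C(CC)(CC)c2ccc(OCC(O)C(C)(C)C)c(C)c2)n1CC` differs from it in one place: (1-methylprop-2-yn-1-yl)oxy in place of (2,2-dimethoxyethyl)amino on a carbonyl carbon. Among the compounds with values here, the only measured step, a 1.4-fold lower number from compound 1 to compound 2 (0.16 log units; within the scatter), lies within the scatter and concerns a different change, so it gives no measured guide to this exchange. No shift beyond the scatter is therefore expected in either direction, and the estimated step is a 1.5-fold lower number from compound 3 to compound 4 (0.16 log units; within the scatter). For compound 4 the estimated value is 10000 nM, with an expected range from 2500 nM to 40000 nM.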

Compound 4, half-maximal inhibitory concentration: 38200 nM
Estimate against measurement, compound 4: 3.8-fold (0.58 log units) below; measured number inside the range.
By their numbers in this assay, from the lowest: compounds 2 and 1 (each within the scatter of the next); then compound 3; then compound 4.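

In this assay, (1-methylprop-2-yn-1-yl)oxy in place of (2,2-dimethoxyethyl)amino on the carbonyl carbon gives a 2.6-fold higher number from compound 3 to compound 4 (0.42 log units; beyond the scatter) and so shows that this position responds to the exchange, modestly and towards weaker inhibition. The entering group has 0 hydrogen-bond donors, the leaving group 1, and it has a triple bond that the leaving group lacks. Nothing at hand bears on the reason for this step.

Which of these differences matters stays open. A plain ethoxy group or a simple ethylamino group on the same carbonyl carbon would help separate them.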